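A few compounds are considered here, and "the series" means these few. Any claim that something is new, unique, unknown or untested is made for them only; others in the source may bear on it.

Compound 1 `Cc1ccccc1COc1ccc(-c2cc(CN3CCN(Cc4ccc(C(F)(F)F)cc4)CC3)no2)cc1`: 6800 nM
Compound 2 `Cc1cccc(COc2ccc(-c3cc(CN4CCN(Cc5ccc(C(F)(F)F)cc5)CC4)no3)cc2)c1`: 2500 nM
Compound 3 `FC(F)(F)c1ccc(CN2CCN(Cc3cc(-c4ccc(OCc5ccccc5Cl)cc4)on3)CC2)cc1`: 3200 nM

These values come from a functional assay on Mahlavu cells (Homo sapiens) for antiproliferative activity, read by sulforhodamine B assay, with a stated time of 72 h; on this read-out higher numbers stand for weaker inhibition and lower numbers for stronger inhibition. Among the three, compound 3 stands second highest; the gap to compound 2 is within the scatter, while compound 1 sits beyond the scatter above it. Compound 4 `FC(F)(F)c1ccc(CN2CCN(Cc3cc(-c4ccc(OCc5cccc(Cl)c5)cc4)on3)CC2)cc1` has not been measured yet. It differs from compound 3 by 3-chlorophenyl in place of 2-chlorophenyl on a saturated chain carbon bound to an oxygen on an aromatic ring. Within the data shown here, the one measured step that bears on this is a 2.7-fold lower number from compound 1 to compound 2 (0.43 log units; beyond the scatter), where the parallel change with a methyl group in place of chlorine gave a modest drop in the number. A step of similar size and direction is therefore expected here, a 2.1-fold lower number from compound 3 to compound 4 (0.33 log units; beyond the scatter). Compound 4 is estimated at 1500 nM, with a range from 700 nM to 3500 nM.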

Compound 4, half-maximal inhibitory concentration: 4100 nM
The estimate for compound 4 lay 2.7-fold (0.44 log units) below the measured number; measured number above the stated range.
By their numbers in this assay, from the lowest: compounds 2, 3, 4 and 1 (each within the scatter of the next, the first and the last beyond it).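

In this assay, 3-chlorophenyl in place of 2-chlorophenyl at this position leaves no readable difference, with a 1.3-fold higher number from compound 3 to compound 4 (0.11 log units; within the scatter), so the modest step seen with the methyl pair does not recur with chloro. Compound 4 also stays within the scatter of both methyl compounds, with a 1.6-fold higher number from compound 2 to compound 4 (0.21 log units; within the scatter) and a 1.7-fold lower number from compound 1 to compound 4 (0.22 log units; within the scatter). Chloro in place of methyl therefore does not give the same step on the two cores: the same change on two cores in this assay, a 2.1-fold lower number (0.33 log units; beyond the scatter) from compound 1 to compound 3 and a 1.6-fold higher number (0.21 log units; within the scatter) from compound 2 to compound 4, 3.5-fold (0.54 log units) apart, beyond the scatter of two such steps.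

Going by these compounds, whether fluoro or methoxy in place of the chloro would give a step beyond the scatter between the 2-substituted and 3-substituted phenyl groups remains open.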